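Trifluoromethyl to 1H-Pyrrol-2-yl: a Step Without Precedent

The compounds below may be only part of what the source reports. "The series", "measured", "known", "first", "only" and "open" are said of these compounds alone.

Three measured compounds share one core and differ only in the group on the terminal amide nitrogen. Compound 1 `C[C@H](NC(=O)C(=O)NC1CCCCC1)C(=O)N[C@@H](CC(=O)O)C(=O)COc1c(F)c(F)cc(F)c1F` carries a cyclohexyl there, and in a functional assay on THP-1 cells (Homo sapiens) for inhibition (a lower number here means a stronger inhibitor, a higher number a weaker inhibitor), compound 1 gives 500 nM. Compound 2 `C[C@H](NC(=O)C(=O)Nc1ccccc1Br)C(=O)N[C@@H](CC(=O)O)C(=O)COc1c(F)c(F)cc(F)c1F` carries a 2-bromophenyl, and compound 2 gives 50 nM. Compound 3 `C[C@H](NC(=O)C(=O)Nc1ccccc1C(F)(F)F)C(=O)N[C@@H](CC(=O)O)C(=O)COc1c(F)c(F)cc(F)c1F` carries a 2-(trifluoromethyl)phenyl, and compound 3 gives 190 nM, the second highest of the three numbers. The steps among them read a 10-fold lower number from compound 1 to compound 2 (1.00 log units; beyond the scatter), a 2.6-fold lower number from compound 1 to compound 3 (0.42 log units; beyond the scatter) and a 3.8-fold higher number from compound 2 to compound 3 (0.58 log units; beyond the scatter).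

Compound 4 `C[C@H](NC(=O)C(=O)Nc1ccccc1-c1ccc[nH]1)C(=O)N[C@@H](CC(=O)O)C(=O)COc1c(F)c(F)cc(F)c1F` introduces a change that none of these steps reproduces: 1H-pyrrol-2-yl in place of trifluoromethyl on an aromatic carbon. Among the measured compounds shown here, two steps bear on it indirectly. The step of a 3.8-fold higher number from compound 2 to compound 3 (0.58 log units; beyond the scatter) shows that exchanging the group at this place shifts the number by a modest amount, and the step of a 2.6-fold lower number from compound 1 to compound 3 (0.42 log units; beyond the scatter) shows that an aryl group on the amide nitrogen already stands lower than cyclohexyl. Nothing measured tells whether a 1H-pyrrol-2-yl behaves more like bromo or like trifluoromethyl, so the author expects only a modest step, most likely downward, with wide uncertainty. Compound 4 is therefore estimated at 100 nM, within a range from 30 nM to 400 nM, which corresponds to an expected 1.9-fold lower number from compound 3 to compound 4 (0.28 log units; within the scatter).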

Compound 4, half-maximal inhibitory concentration: > 32000 nM
Compound 4: only a limit was reported; the forecaster's own chance of this, stated with the estimate: 5%; middle value at least 320-fold (2.50 log units) away from the limit.
By their numbers in this assay, from the lowest: compound 2; then compound 3; then compound 1. At a limit, above all of these: compound 4.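

Compound 4 is reported in this assay only as a limit, not as a number: the limit of > 32000 nM in this assay, at which 1 of the 4 values shown sits. Earlier, exchanging the group on this aromatic carbon had moved the number only modestly, whereas the 1H-pyrrol-2-yl brings a large change in both comparisons, an at least 160-fold higher number from compound 3 to compound 4 (2.22 log units; beyond the scatter) when it replaces trifluoromethyl and an at least 640-fold higher number from compound 2 to compound 4 (2.80 log units; beyond the scatter) when it replaces bromo, so this place proves far less forgiving than compound 2 and compound 3 alone suggested. The lower standing of the aryl groups relative to cyclohexyl also fails to carry over, as the 2-(1H-pyrrol-2-yl)phenyl group reverses the order seen for compound 2 and compound 3 with an at least 64-fold higher number from compound 1 to compound 4 (1.80 log units; beyond the scatter).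

The compounds shown leave open whether the loss follows the five-membered ring itself or the hydrogen on its nitrogen, a question that a pyrrol-2-yl carrying a methyl on that nitrogen, or a phenyl at the same carbon, could help to separate. They also leave open how a simple methyl, a methoxy or an amine would read at this place, and so where between bromo and 1H-pyrrol-2-yl the change begins to matter.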